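The source may report more compounds than this note shows. Statements on the series, on what has been measured and on what is new or still open speak of the compounds shown alone.

Working notes on the series: two compounds have been read in an ADME assay on HCT-116 cells (Homo sapiens) for cytotoxicity, read by CellTiter-Glo, with a stated time of 72 h (a lower number here means a stronger inhibitor, a higher number a weaker inhibitor), and neither has given a number. Compound 1 `Cc1cc(Cl)cc(Cl)c1S(=O)(=O)N1CCC(N2CCC(C)CC2)CC1` reads > 5000 nM as a limit of the assay. Compound 2 `Cc1cc(C)c(S(=O)(=O)N2CCC(N3CCC(CCO)CC3)CC2)c(C)c1` reads > 5000 nM and this too is a limit. The standing of compound 2 is therefore the limit of > 5000 nM in this assay, at which 2 of the 2 values shown sit, and it has no rank within the series.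

Compound 3 `Cc1cc(C)c(S(=O)(=O)N2CCC(N3CCC(C(C)C)CC3)CC2)c(C)c1` carries isopropyl in place of 2-hydroxyethyl on a saturated ring carbon, and the change counts as isopropyl in place of 2-hydroxyethyl on a saturated ring carbon in the comparison. Going by the values given here, no measured step is available as a guide. In this assay the expected change is a number no higher from compound 2 to compound 3 (the limit leaves the size open) and no shift beyond the scatter is expected in either direction. This expectation rests only on compound 2 with its limit of > 5000 nM as the starting point. Compound 3 is estimated at 5000 nM with the range expected to run from 2500 nM to 10000 nM in this estimate.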

Compound 3, half-maximal inhibitory concentration: > 5000 nM
Compound 3 ended at the assay's limit; the forecaster's own chance of this, stated with the estimate: 75%; the middle value sits exactly at the limit.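

In this assay compound 2 and compound 3 both stand at a limit and not at a number, so no step can be read between them. Left open is whether isopropyl and 2-hydroxyethyl differ at all in this read-out, with every compound shown at the same limit: the limit of > 5000 nM in this assay, at which 3 of the 3 values shown sit.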